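A few compounds are considered here, and "the series" means these few. Any claim that something is new, unique, unknown or untested is made for them only; others in the source may bear on it.

Compound 1 `Cc1cc(C)cc(S(=O)(=O)c2c(C(=O)NN3CCOC3=O)[nH]c3ccc(Cl)cc23)c1`: > 100 uM
Compound 2 `CCOC(=O)NNC(=O)c1[nH]c2ccc(Cl)cc2c1S(=O)(=O)c1cc(C)cc(C)c1`: > 100 uM

In a functional assay on cells (Lymphocyte, Homo sapiens) for cytotoxicity (on this read-out lower numbers stand for higher toxicity in this test and higher numbers for lower toxicity in this test), compound 2 gives > 100 uM, which is a limit of the assay and not a number. Compound 1 gives > 100 uM, which is also a limit. For the measured compounds named here, the one measured change is a step that the two limits leave unreadable from compound 1 to compound 2, so it offers no size to carry forward. All that the data show so far is the limit of > 100 uM in this assay, at which 2 of the 2 values shown sit.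

Compound 3 `Cc1cc(C)cc(S(=O)(=O)c2c(C(=O)NNC(=O)NN)[nH]c3ccc(Cl)cc23)c1` keeps the core of compound 2 but carries aminoamino in place of ethoxy on a carbonyl carbon. Going by the values given here, no measured step tests this change, so the expectation is weak. No step beyond the usual scatter is expected in this assay, in either direction. The expected change is a number no higher from compound 2 to compound 3 (the limit leaves the size open). For compound 3 the estimate is 100 uM, with an expected range from 30 uM to 200 uM.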

Compound 3, half-maximal toxic concentration: > 100 uM
Compound 3: only a limit was reported; the forecaster's own chance of this, stated with the estimate: 60%; the middle value lies on the limit itself.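

In this assay compound 3 gives > 100 uM, which is a limit and not a number. The steps linking compound 1, compound 2 and compound 3 therefore cannot be read. The compounds shown leave open how far apart the three lie, and which change, if any, would give a readable number: the limit of > 100 uM in this assay, at which 3 of the 3 values shown sit.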